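Shortening the diethylamino linker in the thienopyrimidine urea series

A few compounds are considered here, and "the series" means these few. Any claim that something is new, unique, unknown or untested is made for them only; others in the source may bear on it.

Among the compounds with values here, compound 2 `CCN(CC)CCCNc1nc(-c2ccc(NC(=O)Nc3ccccc3F)cc2)nc2ccsc12` holds the higher of the two numbers so far; in a functional assay on MKN-45 cells (Homo sapiens) for cytotoxicity, read by MTT assay, with a stated time of 72 h (a lower number here means a stronger inhibitor, a higher number a weaker inhibitor), compound 2 gives 580 nM, while compound 1 `CN(C)CCNc1nc(-c2ccc(NC(=O)Nc3ccccc3F)cc2)nc2ccsc12` gives 530 nM, and the step of a 1.1-fold higher number from compound 1 to compound 2 (0.04 log units; within the scatter) lies within the scatter. Compound 3 `CCN(CC)CCNc1nc(-c2ccc(NC(=O)Nc3ccccc3F)cc2)nc2ccsc12` carries the change (diethylamino in place of (diethylamino)methyl on a saturated chain carbon, two bonds along the chain from a nitrogen on an aromatic ring). Within the data shown here, no measured step isolates this chain shortening; the only step available, a 1.1-fold higher number from compound 1 to compound 2 (0.04 log units; within the scatter), changed the amine substituent and chain together without effect beyond the scatter. No step beyond the scatter is therefore expected in this assay, a 1.1-fold lower number from compound 2 to compound 3 (0.02 log units; within the scatter). Compound 3 is estimated at 550 nM, range 250 nM to 1200 nM.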

Compound 3, half-maximal inhibitory concentration: 1040 nM
Compound 3: middle estimate off by 1.9-fold (0.28 log units), on the low side; measured number inside the range.
By their numbers in this assay, from the lowest: compounds 1, 2 and 3 (each within the scatter of the next).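

In this assay the chain shortening can now be read alone, with the diethylamino end held fixed, and it gives a 1.8-fold higher number from compound 2 to compound 3 (0.25 log units; within the scatter) and so stays within the scatter. The exchange of dimethylamino for diethylamino on the same chain can also be read alone, as a 2.0-fold higher number from compound 1 to compound 3 (0.29 log units; within the scatter) and again within the scatter, so neither change separates these compounds here. Nothing on hand accounts for these numbers. From the compounds shown here alone, it remains open whether a ring amine such as morpholine or piperidine at the chain end, or a chain longer than 3-(diethylamino)propyl, would give a step beyond the scatter.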